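The source may hold more compounds than are shown below. What is called first, only, known or untested is meant among the compounds shown, and "the series" means these compounds.

Compound 1 `CCCCc1nc(/C=N/Nc2nc(N)c3ncn([C@@H]4O[C@H](CO)[C@@H](O)[C@H]4O)c3n2)c(Cl)[nH]1`: 12 nM
Compound 2 `Nc1nc(N/N=C/c2ccc[nH]2)nc2c1ncn2[C@@H]1O[C@H](CO)[C@@H](O)[C@H]1O`: 8 nM
Compound 3 `Nc1nc(N/N=C/c2ccc(-c3ccccn3)cc2)nc2c1ncn2[C@@H]1O[C@H](CO)[C@@H](O)[C@H]1O`: 7540 nM

In an assay on CHO-K1 cells for displacement of a labelled ligand from adenosine receptor A1 (Homo sapiens), read by scintillation counting, with a stated time of 60 min (on this read-out higher numbers stand for weaker inhibition and lower numbers for stronger inhibition), compound 1 gives 12 nM, the second highest of the three numbers. Compound 2 gives 8 nM, a value within the scatter of compound 1, whereas compound 3 gives 7540 nM, a number far above that of compound 1. The change from compound 1 to compound 4 `CN(C)c1ccc(/C=N/Nc2nc(N)c3ncn([C@@H]4O[C@H](CO)[C@@H](O)[C@H]4O)c3n2)cc1` is 4-(dimethylamino)phenyl in place of 2-butyl-5-chloro-1H-imidazol-4-yl on a carbon with a double bond to nitrogen. Among the compounds with values here, the one measured step at this position, a 1.5-fold lower number from compound 1 to compound 2 (0.18 log units; within the scatter), exchanges one five-membered aromatic ring for another and says little about a six-membered ring of carbon only. Within the data shown here, the values of compound 1 and compound 3 show that a six-membered carbon ring bearing a further group at this position went with a much higher number, though no step was computed for that pair and the group differs from the one entering compound 4. Compound 4 is therefore expected to give a higher number than compound 1, a step of a 42-fold higher number from compound 1 to compound 4 (1.62 log units; beyond the scatter), with wide uncertainty. The estimate for compound 4 is 500 nM, between 50 nM and 5000 nM.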

Compound 4, inhibition constant: > 10000 nM
Compound 4: a limit, no number; the forecaster's own chance of this, stated with the estimate: 5%; at least 20-fold (1.30 log units) between middle value and limit.
By their numbers in this assay, from the lowest: compounds 2 and 1 (each within the scatter of the next); then compound 3. At a limit, above all of these: compound 4.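

The value of compound 4 is a limit of the assay and not a number: the limit of > 10000 nM in this assay, at which 1 of the 4 values shown sits. Even so, 4-(dimethylamino)phenyl on the carbon with a double bond to nitrogen is far from interchangeable with either five-membered aromatic ring, with an at least 830-fold higher number from compound 1 to compound 4 (2.92 log units; beyond the scatter) and an at least 1200-fold higher number from compound 2 to compound 4 (3.09 log units; beyond the scatter), whereas the earlier step between those two rings was a 1.5-fold lower number from compound 1 to compound 2 (0.18 log units; within the scatter). Dimethylamino in place of pyridin-2-yl on the aromatic carbon gives an at least 1.3-fold higher number from compound 3 to compound 4 (0.12 log units; that floor lies within the scatter), so the two groups cannot be ordered.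

From the compounds shown here alone, whether an unsubstituted phenyl, or a hydroxyl or methoxy group in place of dimethylamino, would bring the number down remains open. So does whether other five-membered rings, such as furan-2-yl or thiophen-2-yl, would keep numbers like those of compound 1 and compound 2.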